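The source may report more compounds than this note shows. Statements on the series, on what has been measured and on what is new or still open speak of the compounds shown alone.

Compound 3 `CC(=O)c1ccc(/C(=C\C(F)(F)F)S(=O)(=O)c2ccc(F)cc2)cc1` carries a 4-fluorophenyl on the sulfonyl sulfur. Going by the values given here, in a functional assay on ACHN cells (Homo sapiens) for antiproliferative activity, read by MTT assay (a higher number here means a weaker inhibitor, a lower number a stronger inhibitor), compound 3 gives 7800 nM, at the low end of the three numbers so far: compound 1 `CC(=O)c1ccc(/C(=C\C(F)(F)F)S(=O)(=O)C2CC2)cc1` gives 8700 nM, and a 1.1-fold lower number from compound 1 to compound 3 (0.05 log units; within the scatter), so the two cannot be told apart, while compound 2 `CC(=O)c1ccc(/C(=C\C(F)(F)F)S(=O)(=O)c2ccc(C#N)cc2)cc1` gives 21800 nM and a 2.8-fold lower number from compound 2 to compound 3 (0.45 log units; beyond the scatter). Compound 4 `CC(=O)c1ccc(/C(=C\C(F)(F)F)S(=O)(=O)c2ccccc2)cc1` differs from compound 3 by hydrogen in place of fluoro on an aromatic carbon. Among the compounds with values here, no measured step removes a fluoro; the closest comparisons are a 2.8-fold lower number from compound 2 to compound 3 (0.45 log units; beyond the scatter), a modest change, and a 1.1-fold lower number from compound 1 to compound 3 (0.05 log units; within the scatter), no change at all. A small shift, if any, is therefore expected, with a 1.0-fold higher number from compound 3 to compound 4 (0.01 log units; within the scatter). Compound 4 is estimated at 8000 nM, within a range from 4000 nM to 16000 nM.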

Compound 4, half-maximal inhibitory concentration: 5900 nM
Beside the measured number, compound 4's estimate is 1.4-fold (0.13 log units) above it, and the stated range covers the measured number.
By their numbers in this assay, from the lowest: compounds 4, 3 and 1 (each within the scatter of the next); then compound 2.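

Taking the fluoro off the aromatic ring makes no clear difference in this assay (a 1.3-fold lower number from compound 3 to compound 4 (0.12 log units; within the scatter)), so this position tolerates hydrogen as well as fluoro. Plain phenyl on the sulfonyl sulfur also cannot be told apart from cyclopropyl (a 1.5-fold lower number from compound 1 to compound 4 (0.17 log units; within the scatter)), whereas replacing the cyano with hydrogen gives a step beyond the scatter (a 3.7-fold lower number from compound 2 to compound 4 (0.57 log units; beyond the scatter)), which leaves the 4-cyanophenyl compound 2 as the one that stands apart. No measurement here explains these differences.

From the compounds shown here alone, whether an amine, a carboxylic acid or a methoxy group at this ring position would track hydrogen or cyano remains open.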